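A few compounds are considered here, and "the series" means these few. Any claim that something is new, unique, unknown or untested is made for them only; others in the source may bear on it.

Of the compounds shown here, three have so far been tested in a functional assay on A549 cells (Homo sapiens) for inhibition, read by MTT assay, with a stated time of 72 h; a higher number here means a weaker inhibitor, a lower number a stronger inhibitor. Compound 1 `Cn1ccc2c(Oc3ccc(NC(=O)c4cn(-c5ccc(Cl)cc5)c5ccccc5c4=O)cc3F)ccnc21` gives 250 nM in this assay. Compound 2 `Cn1ccc2c(Oc3ccc(NC(=O)c4cn(-c5ccc(Br)cc5)c5ccccc5c4=O)cc3F)ccnc21` differs from compound 1 in a single place, (bromo in place of chloro on an aromatic carbon). In this assay compound 2 gives 1390 nM; the step of a 5.6-fold higher number from compound 1 to compound 2 (0.75 log units; beyond the scatter). Compound 3 `O=C(Nc1ccc(Oc2ccnc3[nH]ccc23)c(F)c1)c1cn(-c2ccc(Cl)cc2)c2ccccc2c1=O` is built on a different core, and that core differs from the core of compound 1 by hydrogen in place of methyl on an aromatic nitrogen; in this assay compound 3 gives 320 nM, and the step of a 1.3-fold higher number from compound 1 to compound 3 (0.11 log units; within the scatter) shows that the two cores behave much alike here.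

Compound 4 `O=C(Nc1ccc(Oc2ccnc3[nH]ccc23)c(F)c1)c1cn(-c2ccc(Br)cc2)c2ccccc2c1=O` has not yet been measured. It stands to compound 3 as compound 2 stands to compound 1: the difference is bromo in place of chloro on an aromatic carbon, the same change, at a place described in the same words. Because a 5.6-fold higher number from compound 1 to compound 2 (0.75 log units; beyond the scatter) gave a weaker inhibitor, a step of similar size is expected for compound 4 on the other core, a 5.0-fold higher number from compound 3 to compound 4 (0.70 log units; beyond the scatter), though this rests on one measured pair only. Compound 4 is accordingly estimated at 1600 nM, with a likely range from 550 nM to 4700 nM.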

Compound 4, half-maximal inhibitory concentration: 950 nM
For compound 4 the middle estimate is 1.7-fold (0.23 log units) above the measured one; the measured number falls inside the stated range.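

In this assay, replacing the 4-chlorophenyl with 4-bromophenyl on the core of compound 3 again gives a weaker inhibitor, a 3.0-fold higher number from compound 3 to compound 4 (0.47 log units; beyond the scatter), and the change carries across the two cores with a similar result: the same change on two cores in this assay, a 5.6-fold higher number (0.75 log units; beyond the scatter) from compound 1 to compound 2 and a 3.0-fold higher number (0.47 log units; beyond the scatter) from compound 3 to compound 4, 1.9-fold (0.27 log units) apart, within the scatter of two such steps. Taking the methyl off the aromatic nitrogen makes no clear difference among the bromo compounds, a 1.5-fold lower number from compound 2 to compound 4 (0.17 log units; within the scatter), and this matches what was seen among the chloro compounds: the same change on two cores in this assay, a 1.3-fold higher number (0.11 log units; within the scatter) from compound 1 to compound 3 and a 1.5-fold lower number (0.17 log units; within the scatter) from compound 2 to compound 4, 1.9-fold (0.27 log units) apart, within the scatter of two such steps. Across these four compounds, then, the halogen swap and the choice of core behave as two largely separate changes, but this rests on just two pairs in one cell assay, so it does not show that the swap would act the same way on any other core, nor why bromo gives the weaker inhibitor.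

As far as these compounds go, it remains open how other groups would behave in the place of the halogen, such as methoxy or a nitrile. From the compounds shown here alone, it is also open whether a longer chain such as ethyl on the aromatic nitrogen would leave the number as little changed as methyl does.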